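Series notes: allyl-bearing bis-arylidene analogues, methoxy to methyl swap

This account rests on a few compounds, and the source may have more. Where it says the series, first, only, none or still open, it means among the compounds named here.

Two fully measured compounds frame the series. Compound 1 `C=CCn1c(=O)/c(=C\c2cccc(Cl)c2Cl)[nH]c(=O)/c1=C\c1ccccc1OC` gives 2000 nM in a functional assay on HL-60 cells (Homo sapiens) for cytotoxicity, read by CCK-8 assay, with a stated time of 72 h; on this read-out lower numbers stand for stronger inhibition and higher numbers for weaker inhibition. Compound 2 `C=CCn1c(=O)/c(=C\c2ccccc2OC)[nH]c(=O)/c1=C\c1ccccc1OC` gives 15700 nM in this assay, the highest of the two numbers reported; compound 3 `COc1ccccc1/C=c1/[nH]c(=O)/c(=C\c2ccccc2OC)[nH]c1=O`, which lacks the allyl group on the ring nitrogen, is reported as "not active" (no number reported) with no number attached, so it cannot be placed on the same scale.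

Among the compounds with values here, the one comparable step is a 7.9-fold higher number from compound 1 to compound 2 (0.89 log units; beyond the scatter), a modest shift in the direction of weaker inhibition when 2-methoxyphenyl replaces 2,3-dichlorophenyl.

Compound 4 `C=CCn1c(=O)/c(=C\c2cccc(C)c2)[nH]c(=O)/c1=C\c1ccccc1OC` differs from compound 2 by 3-methylphenyl in place of 2-methoxyphenyl on a double-bonded chain carbon bound to an aromatic carbon. Within the data shown here, the change again departs from 2-methoxyphenyl at the same position; the only aryl group measured there other than 2-methoxyphenyl, in compound 1 with 2000 nM, gave the lower number. On that single precedent a step back toward stronger inhibition is expected for compound 4, though 3-methylphenyl is not 2,3-dichlorophenyl and the size cannot be read off directly; the expected step is a 2.6-fold lower number from compound 2 to compound 4 (0.42 log units; beyond the scatter).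

Compound 4 is therefore estimated at 6000 nM in this assay, within a range of 2000 nM to 20000 nM.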

Compound 4, half-maximal inhibitory concentration: 16700 nM
Beside the measured number, compound 4's estimate is 2.8-fold (0.44 log units) below it, within the range that was stated.
By their numbers in this assay, from the lowest: compound 1; then compounds 2 and 4 (each within the scatter of the next).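

In this assay, the step of a 1.1-fold higher number from compound 2 to compound 4 (0.03 log units; within the scatter) shows that 3-methylphenyl and 2-methoxyphenyl cannot be told apart on a double-bonded chain carbon bound to an aromatic carbon, so leaving 2-methoxyphenyl at this place does not by itself bring the number down. The step of an 8.4-fold higher number from compound 1 to compound 4 (0.92 log units; beyond the scatter) sets 2,3-dichlorophenyl apart from 3-methylphenyl as well, and among the three aryl groups read at this place, compound 1 alone stands apart, with the lower number, a pattern that rests on these three compounds only. Nothing at hand bears on the reason for this difference.

Still open, on these data alone, is whether a single chlorine, as in 3-chlorophenyl or 2-chlorophenyl, would be enough to reach the number of compound 1, or whether an amine or a carboxylic acid on the same aryl ring would move the read-out at all. Also open, as far as these compounds go, is what a longer chain in place of the allyl group on the ring nitrogen would do, since compound 3, without that allyl group, carries no number for comparison.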